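Methoxy addition on the fluorophenyl ring of compound 2

The compounds below may be only part of what the source reports. "The series", "measured", "known", "first", "only" and "open" are said of these compounds alone.

Measured so far:
- compound 1, `COc1ccc(-n2cnc3cnc(-c4ccc(F)cc4)cc32)cc1OC`: 780 nM
- compound 2, `Fc1ccc(-c2cc3c(cn2)ncn3-c2ccc(OC(F)F)cc2)cc1`: 10000 nM

In a functional assay on HL-60 cells (Homo sapiens) for activation, read by flow cytometry, with a stated time of 4 days (on this read-out lower numbers stand for an effect already at smaller amounts and higher numbers for an effect only at larger amounts of compound), compound 2 gives 10000 nM, the highest of the two numbers; its nearest neighbour is compound 1 at 780 nM, a gap beyond the scatter. Compound 3, `COc1cc(F)ccc1-c1cc2c(cn1)ncn2-c1ccc(OC(F)F)cc1`, differs from compound 2 by methoxy in place of hydrogen on an aromatic carbon. Within the data shown here, no measured pair shows this change, so its effect in this assay cannot be read from the data; the step is expected to be small, in either direction, as a 1.7-fold lower number from compound 2 to compound 3 (0.22 log units; within the scatter). Compound 3 is therefore expected near 6000 nM, between 1500 nM and 20000 nM.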

Compound 3, half-maximal effective concentration: 93 nM
Compound 3: the middle estimate sits 65-fold (1.81 log units) above what was measured, and the stated range ends above it.
By their numbers in this assay, from the lowest: compound 3; then compound 1; then compound 2.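

In this assay, among these compounds, the change from 4-fluorophenyl to 4-fluoro-2-methoxyphenyl gives a 110-fold lower number from compound 2 to compound 3 (2.03 log units; beyond the scatter) and is the first single-place step. The carbon ortho to a large group is therefore highly sensitive to substitution, and a methoxy of only 2 heavy atoms is enough to produce this large step. No available evidence explains the step.

From the compounds shown here alone, it remains open whether a hydroxyl, an ethoxy or a dimethylamino group at this carbon would give a similar step. Going by these compounds, whether methoxy at this carbon acts the same way on compound 1 also remains open.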